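The source may report more compounds than this note shows. Statements on the series, on what has been measured and on what is new or still open speak of the compounds shown alone.

Compound 2 `O=C(/C=C/c1cc([N+](=O)[O-])ccc1Cl)c1ccc[nH]1` has the highest number of the two measured in a functional assay on HeLa cells (Homo sapiens) for inhibition, read by MTT assay, with a stated time of 48 h (a lower number here means a stronger inhibitor, a higher number a weaker inhibitor), where compound 2 gives 68000 nM. Within the data shown here, its nearest neighbour, compound 1 `O=C(/C=C/c1cccc([N+](=O)[O-])c1)c1ccc[nH]1`, gives 32000 nM in this assay, and the single measured step, a 2.1-fold higher number from compound 1 to compound 2 (0.33 log units; beyond the scatter), concerns the chloro group and not the ring attached to the carbonyl carbon. Compound 3 `O=C(/C=C/c1cc([N+](=O)[O-])ccc1Cl)c1ccco1` differs from compound 2 by furan-2-yl in place of 1H-pyrrol-2-yl on a carbonyl carbon. Among the measured compounds shown here, no measured step bears on this exchange, so no step beyond the scatter is expected: compound 3 is estimated at 68000 nM, within a range from 25000 nM to 180000 nM, which corresponds to an expected step of no change at the digits printed from compound 2 to compound 3 (within the scatter).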

Compound 3, half-maximal inhibitory concentration: > 100000 nM
Compound 3 ended at the assay's limit; the forecaster's own chance of this, stated with the estimate: 10%; at least 1.4-fold (0.16 log units) between middle value and limit.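

In this assay, furan-2-yl in place of 1H-pyrrol-2-yl on a carbonyl carbon gives an at least 1.4-fold higher number from compound 2 to compound 3 (0.16 log units; that floor lies within the scatter). Among these compounds, this is the first reading on this position, and it sets only a floor for the change, so its true size stays unknown and may lie within the scatter or well beyond it. The value of compound 3 is a limit and not a number: the limit of > 100000 nM in this assay, at which 1 of the 3 values shown sits.

The compounds shown leave open how this position responds to other groups on the carbonyl carbon, such as a phenyl ring or an amine. They also leave open whether furan-2-yl gives a similar step on the core of compound 1, which has no chloro group.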